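The source may hold more compounds than are shown below. What is called first, only, known or untested is meant among the compounds shown, and "the series" means these compounds.

Measured so far:
- compound 2, `C=CCOc1ccc([C@H](CO)NC[C@H]2NC[C@H](O)[C@@H]2O)cc1`: > 200000 nM
- compound 1, `OC[C@H](NC[C@H]1NC[C@H](O)[C@@H]1O)c1ccc(-c2ccsc2)cc1`: "not active" (no number reported)

Notes on the series. In a functional assay on BT-474 cells (Homo sapiens) for cytotoxicity, read by colorimetric assay, with a stated time of 72 h (a higher number here means a weaker inhibitor, a lower number a stronger inhibitor), compound 2 gives > 200000 nM, which is a limit of the assay and not a number. Compound 1 is recorded in this assay as "not active" (no number reported), again without a number. So compound 2 stands at the limit of > 200000 nM in this assay, at which 1 of the 2 values shown sits, and the other entry gives nothing to rank it against; no step between measured compounds can be drawn.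

Compound 3, `OC[C@H](NC[C@H]1NC[C@H](O)[C@@H]1O)c1ccc(OCc2ccccc2)cc1`, remains to be measured in this assay. It differs from compound 2 by phenyl in place of vinyl on a saturated chain carbon bound to an oxygen on an aromatic ring. Among the compounds with values here, nothing measured here tells how this change moves the read-out: both entries so far sit outside the numerical range, and a difference of this kind has no measured counterpart.

The expectation is therefore that compound 3 stays where compound 2 stands, and the expected step of a number no higher from compound 2 to compound 3 (the limit leaves the size open) is none beyond the scatter. Compound 3 is estimated at 200000 nM, with a range from 50000 nM to 600000 nM, and most likely the assay again reports only a limit.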

Compound 3, half-maximal inhibitory concentration: "not active" (no number reported)
Compound 3 has no reported number here, and the estimate cannot be compared.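

In this assay compound 3 is recorded as "not active" (no number reported) and gives no number, so no step can be read between compound 2 and compound 3. Compound 2 stands at a limit of the assay and not at a number: the limit of > 200000 nM in this assay, at which 1 of the 3 values shown sits.

The compounds shown leave open whether in this assay any substituent on the shared core gives a measurable value.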